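The compounds below may be only part of what the source reports. "The series", "measured", "known", "first", "only" and "open" are said of these compounds alone.

Measured compounds in a functional assay on SK-N-MC cells (Homo sapiens) for cytotoxicity, read by MTT assay; a lower number here means a stronger inhibitor, a higher number a weaker inhibitor:

- compound 1, `COc1ccc(/C=C2\CCC/C(=C\c3ccccc3[N+](=O)[O-])C2=O)cc1`, gives 75 ug/mL
- compound 2, `COc1cc(/C=C2\CCC/C(=C\c3ccccc3[N+](=O)[O-])C2=O)cc(Br)c1OC`, gives 6.24 ug/mL
- compound 3, `CCCOc1c(Br)cc(/C=C2\CCC/C(=C\c3ccccc3[N+](=O)[O-])C2=O)cc1OC`, gives 3.5 ug/mL

Compound 2 stands second highest of these three numbers. Its nearest neighbour is compound 3, reached by the step of a 1.8-fold lower number from compound 2 to compound 3 (0.25 log units; within the scatter), which lies within the scatter. Its furthest neighbour is compound 1, whose number is higher by a gap beyond the scatter.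

Compound 4, `COc1cc(/C=C2\CCC/C(=C\c3cccc([N+](=O)[O-])c3)C2=O)cc(Br)c1OC`, has not yet been measured. It keeps every atom of compound 2 but joins them differently: 3-nitrophenyl in place of 2-nitrophenyl on a double-bonded chain carbon bound to a double-bonded ring carbon. The ring carrying the bromine and the two alkoxy groups is untouched.

For the measured compounds named here, only one measured step exists, the one from compound 2 to compound 3, and it concerns the alkoxy chain on the other ring, not the nitrophenyl group. It was small, within the scatter, and says nothing about moving the nitro group from one ring carbon to another. Going by the values given here, no measured step therefore bears on this change. The expectation is a step of a 1.0-fold higher number from compound 2 to compound 4 (0.02 log units; within the scatter), that is, no change beyond the scatter in this assay. Compound 4 is therefore estimated at 6.5 ug/mL, with a range from 2.5 ug/mL to 17 ug/mL.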

Compound 4, half-maximal inhibitory concentration: 16.7 ug/mL
Compound 4: the middle estimate sits 2.6-fold (0.41 log units) below what was measured; the range from low to high includes it.
By their numbers in this assay, from the lowest: compounds 3 and 2 (each within the scatter of the next); then compound 4; then compound 1.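

Moving the nitro group adds and removes no atoms, yet in this assay it gives a 2.7-fold higher number from compound 2 to compound 4 (0.43 log units; beyond the scatter) and so 2-nitrophenyl and 3-nitrophenyl cannot be treated as interchangeable at this place on the shared core, even though the step is modest. The only earlier step between compounds differing in one place concerned the alkoxy chain on the other ring and stayed within the scatter, so this is the first single change shown to move the number beyond it, and the first reading of any kind at this position. Nothing available here accounts for why the placement of the nitro group matters in these cells.

From the compounds shown here alone, the move has been read only once, on the background of compound 2, so it remains open whether it would give a similar step on compound 3, which carries the longer chain. Also open, going by these compounds, is how the number would respond if the nitro group on this phenyl ring gave way to a different group, such as a nitrile, an amine or a carboxylic acid.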